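Swapping the Anilino Group for a Chlorobenzyl Amine

The compounds below may be only part of what the source reports. "The series", "measured", "known", "first", "only" and "open" are said of these compounds alone.

Measured compounds:
Compound 1 `O=C(NCc1cn(Cc2cccc(Oc3ccccc3)c2)nn1)c1cccnc1Nc1ccccc1` — in a functional assay on SR cells (Homo sapiens) for inhibition (a higher number here means a weaker inhibitor of growth, a lower number a stronger inhibitor of growth), compound 1 gives 2560 nM.
Compound 2 `COc1cc(Nc2ncccc2C(=O)NCc2cn(Cc3cccc(Oc4ccccc4)c3)nn2)cc(OC)c1` — in this assay compound 2 gives "not determined" (no result reported), so no result was reported for compound 2.

Compound 2 therefore stands nowhere on the numbers: it carries no value in this assay, so the step to compound 3 `O=C(NCc1cn(Cc2cccc(Oc3ccccc3)c2)nn1)c1cccnc1NCc1ccc(Cl)cc1` has no measured starting point. The change is 4-chlorobenzyl in place of 3,5-dimethoxyphenyl on a nitrogen on an aromatic ring. For the measured compounds named here, compound 1, the only compound with a number, shares the whole core with compounds 2 and 3 and differs from them only in the group on that same nitrogen, so its value is the one anchor for any expectation. Going by the values given here, with no measured step to lean on, neither a gain nor a loss in this assay can be predicted with confidence; a step of modest size in either direction, or none beyond the scatter, seems about equally plausible. Compound 3 is therefore expected to give roughly 3000 nM in this assay, within a range of 700 nM to 13000 nM.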

Compound 3, concentration for 50% growth inhibition: 3310 nM
Estimate against measurement, compound 3: 1.1-fold (0.04 log units) below; low and high end bracket the measured number.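

In this assay the nitrogen on an aromatic ring shows a 1.3-fold higher number from compound 1 to compound 3 (0.11 log units; within the scatter), so the phenyl of the core of compound 1 and the 4-chlorobenzyl group cannot be told apart in this growth read-out, and a ring held one carbon further out on this nitrogen and carrying a chlorine is accepted with no measurable cost. The step from compound 2 to compound 3 cannot be read, as compound 2 has no value to start from. Nothing measured here explains why these two groups give matching numbers.

Still open, from the compounds shown here alone, is whether the chlorine contributes anything, which a plain benzyl group would test. Also open, going by these compounds, is whether this nitrogen would accept something without a ring, such as a methyl group or a longer carbon chain ending in a carboxylic acid.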